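Working notes on the shared-core amide series, compound 4

This account rests on a few compounds, and the source may have more. Where it says the series, first, only, none or still open, it means among the compounds named here.

Measured in a functional assay on HL-60 cells (Homo sapiens), with a stated time of 4 days; on this read-out lower numbers stand for stronger inhibition and higher numbers for weaker inhibition:
compound 1, `O=C(NC1CCCCC1)c1nc[nH]c1C(=O)Nc1ccc(Cl)c(Cl)c1`: 12300 nM
compound 2, `COc1ccc(CNC(=O)c2[nH]cnc2C(=O)Nc2ccc(Cl)c(Cl)c2)cc1`: 18300 nM
compound 3, `O=C(NCc1ccc(-c2ccccc2)cc1)c1nc[nH]c1C(=O)Nc1ccc(Cl)c(Cl)c1`: 2900 nM

All three compounds share one core and differ only in the group carried on the amide-type nitrogen. Compound 2 gives the highest number of the three in this assay, but its gap to compound 1 lies within the scatter, so no order between compound 1 and compound 2 can be read from these numbers. Only compound 3 stands apart, with a number that is lower by an amount beyond the scatter; among the three, compound 3 is the one that inhibits most strongly.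

Compound 4, `COC(=O)[C@H](NC(=O)c1[nH]cnc1C(=O)Nc1ccc(Cl)c(Cl)c1)C(C)C`, is not yet measured. It arises from compound 2 by the change (1-(methoxycarbonyl)-2-methylpropyl in place of 4-methoxybenzyl on an amide-type nitrogen). Within the data shown here, the group entering is one with no ring, whereas compound 3, the only compound that separates from the rest, carries a second aromatic ring on that nitrogen. Nothing measured here supports a gain from a ring-free group, and nothing shows a loss either; the change is expected to give a step from compound 2 to compound 4 of a 1.2-fold lower number from compound 2 to compound 4 (0.09 log units; within the scatter), that is, none beyond the scatter. Compound 4 is therefore estimated at 15000 nM, with a range of 5000 nM to 45000 nM.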

Compound 4, half-maximal inhibitory concentration: 4900 nM
Compound 4: the middle estimate sits 3.1-fold (0.49 log units) above what was measured; the measured number lies below the stated range.
By their numbers in this assay, from the lowest: compounds 3 and 4 (each within the scatter of the next); then compounds 1 and 2 (each within the scatter of the next).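

In this assay, among these compounds, 1-(methoxycarbonyl)-2-methylpropyl in place of 4-methoxybenzyl on the amide-type nitrogen gives a 3.7-fold lower number from compound 2 to compound 4 (0.57 log units; beyond the scatter) and is the first step that can be read between two measured compounds differing in one place. Compound 3 therefore no longer stands alone: compound 3 and compound 4 lie within the scatter of each other, and a group with no ring on this nitrogen keeps company with the biphenyl-type group of compound 3, while compound 1 and compound 2, which also carry a ring there, remain at the higher numbers, so ring content alone does not sort these four compounds. Nothing available here bears on the reason for this step.

The compounds shown leave open whether the step goes with the methoxycarbonyl part, with the branched chain, or with both, a question that a carboxylic acid or a primary amide in place of the methyl ester, or a plain isobutyl chain, would address. They also leave open what the opposite configuration at the defined stereocentre would give in this assay on this nitrogen.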